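Thiazole acyl-hydrazones: aryl swap on the acylurea carbonyl

A few compounds are considered here, and "the series" means these few. Any claim that something is new, unique, unknown or untested is made for them only; others in the source may bear on it.

Compound 1 `CN(C(=O)NC(=O)c1ccc(F)c(F)c1)c1nc(C(F)(F)F)c(C(=O)N/N=C/c2ccc([N+](=O)[O-])cc2)s1`: 4.81 ug/mL
Compound 2 `CN(C(=O)NC(=O)c1cccc([N+](=O)[O-])c1)c1nc(C(F)(F)F)c(C(=O)N/N=C/c2ccccc2C(F)(F)F)s1`: 4.73 ug/mL
Compound 3 `CN(C(=O)NC(=O)c1ccc(C(F)(F)F)cc1)c1nc(C(F)(F)F)c(C(=O)N/N=C/c2ccc(C(F)(F)F)cc2)s1`: > 100 ug/mL

In a functional assay on MCF7 cells (Homo sapiens) for inhibition, read by MTT assay, with a stated time of 72 h (a lower number here means a stronger inhibitor, a higher number a weaker inhibitor), compound 2 gives 4.73 ug/mL. Of the two numeric values this is the lower one, yet its gap to compound 1 lies within the scatter, so the two cannot be told apart. Compound 3 gives only a limit, > 100 ug/mL, in this assay; that reading is the limit of > 100 ug/mL in this assay, at which 1 of the 3 values shown sits.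

Compound 4 `CN(C(=O)NC(=O)c1ccc(F)c(F)c1)c1nc(C(F)(F)F)c(C(=O)N/N=C/c2ccccc2C(F)(F)F)s1` is not yet measured. It differs from compound 2 in one place: 3,4-difluorophenyl in place of 3-nitrophenyl on a carbonyl carbon. Compound 1 carries the same 3,4-difluorophenyl on that carbonyl carbon and gives 4.81 ug/mL in this assay, close to compound 2. The step of a 1.1-fold higher number from compound 2 to compound 4 (0.02 log units; within the scatter) is therefore expected to stay within the scatter, with no clear direction. Compound 4 is estimated at 5 ug/mL, within 2 ug/mL to 15 ug/mL.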

Compound 4, half-maximal inhibitory concentration: 8.21 ug/mL
Compound 4: the middle estimate sits 1.6-fold (0.22 log units) below what was measured, within the range that was stated.
By their numbers in this assay, from the lowest: compounds 2, 1 and 4 (each within the scatter of the next). At a limit, above all of these: compound 3.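

In this assay the change on this carbonyl carbon gives a 1.7-fold higher number from compound 2 to compound 4 (0.24 log units; within the scatter), so 3,4-difluorophenyl and 3-nitrophenyl cannot be told apart here when the rest of the molecule is held constant. On the carbon with a double bond to nitrogen, the change gives a 1.7-fold higher number from compound 1 to compound 4 (0.23 log units; within the scatter), so those two groups cannot be told apart either. No measurement shown bears on a cause for these steps.

As far as these compounds go, it remains open whether an amine or a carboxylic acid on the aryl ring at this carbonyl carbon would stay within the scatter of compound 2. From the compounds shown here alone, compound 3 reads only as a limit, and which of its differences matters is also open.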